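Ethyl in place of fluoro on the anilide ring

The source may hold more compounds than are shown below. What is called first, only, known or untested is meant among the compounds shown, and "the series" means these compounds.

The three measured compounds share one core and differ only in the aryl group on the amide nitrogen. Compound 1 `O=C(CSc1nc(Nc2ccccc2)c2ccccc2n1)Nc1ccccc1Cl` carries a 2-chlorophenyl there, and in a functional assay on MGC-803 cells (Homo sapiens) for inhibition, read by MTT assay, with a stated time of 72 h (on this read-out lower numbers stand for stronger inhibition and higher numbers for weaker inhibition), compound 1 gives 24800 nM. Compound 2 `O=C(CSc1nc(Nc2ccccc2)c2ccccc2n1)Nc1cccc(F)c1` carries a 3-fluorophenyl, and compound 2 gives 12700 nM. Compound 3 `O=C(CSc1nc(Nc2ccccc2)c2ccccc2n1)Nc1ccc(F)cc1` carries a 4-fluorophenyl. For compound 3 only a limit of the assay is known, > 50000 nM, so that compound 3 stands at the limit of what the assay reports (the limit of > 50000 nM in this assay, at which 1 of the 3 values shown sits). The step of a 2.0-fold lower number from compound 1 to compound 2 (0.29 log units; within the scatter) lies within the scatter, as does an at least 2.0-fold higher number from compound 1 to compound 3 (0.30 log units; that floor lies within the scatter), whereas an at least 3.9-fold higher number from compound 2 to compound 3 (0.59 log units; beyond the scatter) is beyond it.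

Compound 4 `CCc1ccc(NC(=O)CSc2nc(Nc3ccccc3)c3ccccc3n2)cc1` is not yet measured. It differs from compound 3 by ethyl in place of fluoro on an aromatic carbon. Going by the values given here, no measured step swaps fluoro for ethyl, and none changes a group placed para to a large group; the steps above all concern the ring position or the halogen. They therefore give no firm direction, and the limit for compound 3 leaves only a floor. The author expects for compound 4 a value of 40000 nM, between 12000 nM and 130000 nM, which means an expected step of an at least 1.2-fold lower number from compound 3 to compound 4 (0.09 log units; that floor lies within the scatter).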

Compound 4, half-maximal inhibitory concentration: > 50000 nM
Compound 4 gave a limit, no number (the forecaster's own chance of this, stated with the estimate: 45%); middle value at least 1.2-fold (0.09 log units) away from the limit.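

Compound 3 and compound 4 both end at a limit of this assay rather than at a number, so the step between them cannot be read, and fluoro and ethyl cannot be ordered at this place: the limit of > 50000 nM in this assay, at which 2 of the 4 values shown sit.

Set against the 3-fluorophenyl, the 4-ethylphenyl gives an at least 3.9-fold higher number from compound 2 to compound 4 (0.59 log units; beyond the scatter), the same floor that the 4-fluorophenyl gave, so two different groups para to a large group now both stand beyond the scatter from compound 2 on the weaker side. Set against the 2-chlorophenyl, the 4-ethylphenyl gives an at least 2.0-fold higher number from compound 1 to compound 4 (0.30 log units; that floor lies within the scatter), and this floor fixes no order between the two compounds.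

From the compounds shown here alone, how far compound 3 and compound 4 lie past the limit stays open, and so does whether ethyl and fluoro differ at all at this place. Going by these compounds, it is also open whether an amine, a carboxylic acid or a longer chain on the same aromatic carbon would bring a readable number back into this assay.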